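Changing the amide group of compound 2

The source may hold more compounds than are shown below. What is called first, only, known or untested is meant among the compounds shown, and "the series" means these compounds.

Measured so far in a functional assay on DU-145 cells (Homo sapiens) for antiproliferative activity, read by sulforhodamine B assay, with a stated time of 3 days; on this read-out lower numbers stand for stronger inhibition of growth and higher numbers for weaker inhibition of growth:
Compound 1 `O=C(Nc1cccc(Nc2ncc(F)c(Nc3ccc(F)cc3)n2)c1)c1cccc([N+](=O)[O-])c1`: 12600 nM
Compound 2 `CN1CCC(C(=O)Nc2cccc(Nc3ncc(F)c(Nc4ccc(F)cc4)n3)c2)CC1`: 1150 nM

Of the two measured compounds, compound 2 has the lower number, at 1150 nM. Compound 3 `CN(C)c1ccc(C(=O)Nc2cccc(Nc3ncc(F)c(Nc4ccc(F)cc4)n3)c2)cc1` has not yet been measured and differs from compound 2 in one group: 4-(dimethylamino)phenyl in place of 1-methylpiperidin-4-yl on a carbonyl carbon. Among the compounds with values here, only one measured step bears on this change, and it falls at the same place: an 11-fold lower number from compound 1 to compound 2 (1.04 log units; beyond the scatter), a large step, with 1-methylpiperidin-4-yl in place of 3-nitrophenyl. Compound 3 again carries a six-membered aromatic ring of carbon only on the carbonyl carbon, as compound 1 does with its 3-nitrophenyl group at 12600 nM. The two aromatic groups are not the same, however, and this single comparison is thin support, so only part of that distance is expected to be retraced. In this assay the expected change is a higher number, an estimated 3.0-fold higher number from compound 2 to compound 3 (0.48 log units; beyond the scatter). For compound 3 the estimated value is 3500 nM, with an expected range of 1100 nM to 11000 nM.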

Compound 3, concentration for 50% growth inhibition: > 10000 nM
Compound 3: a limit, no number; the forecaster's own chance of this, stated with the estimate: 8%; middle value at least 2.8-fold (0.45 log units) from the limit.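

In this assay the result for compound 3 is a limit of the assay and not a number: the limit of > 10000 nM in this assay, at which 1 of the 3 values shown sits. Even so, the step reads as an at least 8.6-fold higher number from compound 2 to compound 3 (0.93 log units; beyond the scatter), so on this carbonyl carbon 1-methylpiperidin-4-yl now gives the lower number against a second aromatic group, 4-(dimethylamino)phenyl, and not only against 3-nitrophenyl. The step between compound 1 and compound 3 cannot be read, so these two aromatic groups remain unordered.

The compounds shown leave open whether the lower number of compound 2 goes with the non-aromatic ring itself or with its ring nitrogen. A cyclohexyl group, which has no nitrogen, and a piperidin-4-yl group without the methyl on nitrogen would each bear on that question.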